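Methyl to ethyl on compound 3

The source may report more compounds than this note shows. Statements on the series, on what has been measured and on what is new or still open speak of the compounds shown alone.

In a functional assay on FM3A cells (Mus musculus) for cytotoxicity (a higher number here means that more compound is needed for the effect, a lower number that less compound is needed), compound 3 (`COOC1(OC)CCCCCCCCCCC1`) gives a value of 19000 nM and stands close to compound 1 (`CCOOC1(OOCC)CCCCCCCCCCC1`), which gives 10000 nM in the same test. These two values lie within the usual scatter of each other. Compound 2 (`COOC1(OOCCC(=O)OC)CCCCCCCCCCC1`) gives 1400 nM and sits well apart from them. Putting methyl in place of its 2-(methoxycarbonyl)ethoxy gives a 14-fold higher number from compound 2 to compound 3 (1.13 log units; beyond the scatter) as a large step.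

Compound 4 (`CCOOC1(OC)CCCCCCCCCCC1`) changes a different place on compound 3 (methyl in place of hydrogen on a saturated chain carbon bound to an oxygen on an unsaturated carbon), turning methoxyoxy into ethoxyoxy. Among the compounds with values here, the one measured step does not touch this place, so it offers little guidance here. Compound 1 is a better guide, since it carries ethoxyoxy groups and its value (10000 nM) stays within the scatter of the value of compound 3. No clear shift is therefore expected in this assay and the estimated outcome is a 1.3-fold lower number from compound 3 to compound 4 (0.10 log units; within the scatter) as a step inside the scatter. The value expected for compound 4 is 15000 nM in an estimated range from 6000 nM to 35000 nM for this test.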

Compound 4, half-maximal effective concentration: 26000 nM
The estimate for compound 4 lay 1.7-fold (0.24 log units) below the measured number; low and high end bracket the measured number.
By their numbers in this assay, from the lowest: compound 2; then compounds 1, 3 and 4 (each within the scatter of the next, the first and the last beyond it).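

In this assay, turning methoxyoxy into ethoxyoxy gives a 1.4-fold higher number from compound 3 to compound 4 (0.14 log units; within the scatter), so at this place the added methyl leaves no readable change. The change at the other place, methyl in place of ethoxy on an oxygen on a saturated carbon, gives a 2.6-fold higher number from compound 1 to compound 4 (0.41 log units; beyond the scatter), a modest step that lies beyond the scatter, so the two places on the shared core do not respond alike to these changes. No supporting measurement is available to explain either step.

Still open, from the compounds shown here alone, is whether a longer chain such as propyl, or a chain ending in a carboxylic acid, would shift the number at the place changed here. Also open, going by these compounds, is whether methoxyoxy to ethoxyoxy stays this small a step when the other place carries the 2-(methoxycarbonyl)ethoxy group of compound 2.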